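A few compounds are considered here, and "the series" means these few. Any claim that something is new, unique, unknown or untested is made for them only; others in the source may bear on it.

Notes on the series, read in an assay for inhibition of Voltage-dependent L-type calcium channel subunit alpha-1C (Rattus norvegicus), read by patch clamp, tested at 10 uM; a lower number here means less inhibition, a higher number more inhibition at the concentration tested (going by the name of the read-out). Compound 1 `CC1=C(C(=O)OCC(C)C)C(c2cc(Br)cc([N+](=O)[O-])c2O)C2=C(CCC(C)(C)C2=O)N1` gives 10%, and compound 3 `CC1=C(C(=O)OCC(C)C)C(c2cc([N+](=O)[O-])cc(Br)c2O)C2=C(CCC(C)(C)C2=O)N1` gives 15%; those two numbers lie within the usual scatter of one another, so nothing separates them. Compound 2 `COC(=O)C1=C(C)NC2=C(C(=O)C(C)(C)CC2)C1c1cc([N+](=O)[O-])ccc1O` is reported only as a limit of the assay, < 30%, with no number behind it. Where compound 2 stands among the three is therefore open: it is the one reading of the three that sits at the limit of < 30% in this assay, at which 1 of the 3 values shown sits, and its true value could lie anywhere beneath that limit, including near the numbers seen for compound 1 and compound 3.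

Compound 4 `CC1=C(C(=O)OCc2ccccc2)C(c2cc([N+](=O)[O-])ccc2O)C2=C(CCC(C)(C)C2=O)N1` has not been measured. It differs from compound 2 in one place: phenyl in place of hydrogen on a saturated chain carbon bound to an oxygen next to a carbonyl group. Among the measured compounds shown here, no pair of measured compounds in this set differs only at the methoxycarbonyl, so no measured step sizes this change. Compound 1 and compound 3 both read low, and nothing in the set points to a large move in either direction. The step that the limit leaves unreadable from compound 2 to compound 4 is therefore expected to stay within the scatter, with no direction asserted. For compound 4 the estimate in this assay is 15%, in a range from 0% to 35%, with a fair chance the result is again reported only as a limit.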

Compound 4, a percentage reported as inhibition, at one concentration (the size of the read-out at that concentration, not a potency): 70%
Compound 4: the middle estimate sits 55 percentage points below what was measured; measured number outside the range, above it.
By their numbers in this assay, from the lowest: compounds 1 and 3 (each within the scatter of the next); then compound 4.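

In this assay, the methoxycarbonyl proves to be a place where a single change registers: going from methoxycarbonyl to benzyloxycarbonyl gives a number at least 40 percentage points higher from compound 2 to compound 4 (beyond the scatter). Among the compounds shown here, this is the first measured step at this place, and it shows that phenyl in place of hydrogen on a saturated chain carbon bound to an oxygen next to a carbonyl group can move the reading beyond the scatter, which the earlier compounds gave no means of seeing. Compound 2 is reported only as a limit of the assay, so the step has a lower bound and no exact size: the limit of < 30% in this assay, at which 1 of the 4 values shown sits.

From the compounds shown here alone, whether the step needs the aromatic ring or only a larger group at this place stays open, and a cyclohexylmethyl in place of the benzyl would separate the two. Compound 1 and compound 3 carry a different group here but differ from compound 4 in more than one place, so they do not show how the reading follows the size of this group.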